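Bromofuran to chlorophenyl on the double-bonded chain carbon

The source may hold more compounds than are shown below. What is called first, only, known or untested is meant among the compounds shown, and "the series" means these compounds.

Compound 2 `COc1ccc(CNC(=O)/C(C#N)=C/c2ccc(Br)o2)cc1` carries a 5-bromofuran-2-yl group on a double-bonded chain carbon bound to a double-bonded chain carbon. Among the compounds with values here, in a functional assay on BE(2)-C cells (Homo sapiens) for inhibition, read by MTT assay, with a stated time of 72 h (a higher number here means a weaker inhibitor of growth, a lower number a stronger inhibitor of growth), compound 2 gives 13000 nM, the lowest of the two numbers measured so far. Its nearest neighbour is compound 1 `COc1ccc(CNC(=O)/C(C#N)=C/c2ccc[nH]2)cc1`, which in this assay gives 47000 nM; the step of a 3.6-fold lower number from compound 1 to compound 2 (0.56 log units; beyond the scatter) came with 5-bromofuran-2-yl in place of 1H-pyrrol-2-yl at that chain carbon.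

Compound 3 `COc1ccc(CNC(=O)/C(C#N)=C/c2ccc(Cl)cc2)cc1` differs from compound 2 by 4-chlorophenyl in place of 5-bromofuran-2-yl on a double-bonded chain carbon bound to a double-bonded chain carbon. Within the data shown here, no measured step exchanges a five-membered ring for a six-membered ring of carbon only at this position, so the only guide is a 3.6-fold lower number from compound 1 to compound 2 (0.56 log units; beyond the scatter), which shows that changing the ring on this chain carbon shifted the number by a modest amount. A shift of about that size at most, in either direction, is therefore expected in this assay, and the estimate stays close to compound 2 with a broad range. Compound 3 is expected to give 12000 nM in this assay, within 3500 nM to 40000 nM. That estimate corresponds to an expected step of a 1.1-fold lower number from compound 2 to compound 3 (0.03 log units; within the scatter) that is not expected to exceed the scatter.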

Compound 3, concentration for 50% growth inhibition: 12000 nM
Compound 3: the middle estimate sits on the measured number at the digits printed; low and high end bracket the measured number.
By their numbers in this assay, from the lowest: compounds 3 and 2 (each within the scatter of the next); then compound 1.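

In this assay, the step of a 1.1-fold lower number from compound 2 to compound 3 (0.03 log units; within the scatter) shows that at this chain carbon a six-membered aromatic ring of carbon only and a five-membered aromatic ring with 1 hetero atom cannot be told apart, even though 4-chlorophenyl has no hydrogen-bond acceptor and 5-bromofuran-2-yl has one. The step of a 3.9-fold lower number from compound 1 to compound 3 (0.59 log units; beyond the scatter) places 4-chlorophenyl with 5-bromofuran-2-yl, so among these three compounds the group that stands apart is 1H-pyrrol-2-yl, and ring size does not separate the numbers. No independent measurement is available to account for this result.

Both groups that share the lower numbers carry a halogen and the group in compound 1 carries none, so these compounds cannot separate the halogen from the change of ring itself. As far as these compounds go, it remains open how a plain phenyl ring without chlorine, or a ring bearing an amine or a carboxylic acid, would read on this chain carbon, and whether changes elsewhere on the shared core would follow the same course.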